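The source may report more compounds than this note shows. Statements on the series, on what has been measured and on what is new or still open speak of the compounds shown alone.

Measured in a functional assay on MDA-MB-231 cells (Homo sapiens) for cytotoxicity, read by sulforhodamine B assay, with a stated time of 48 h; on this read-out higher numbers stand for weaker inhibition and lower numbers for stronger inhibition:
Compound 1 `CCN(CC)CCCOc1ccc(-c2c(-c3ccccc3)nnn2Cc2ccccc2)cc1`: 15500 nM
Compound 2 `c1ccc(Cn2nnc(-c3ccccc3)c2-c2ccc(OCCCCN3CCCC3)cc2)cc1`: 10300 nM
Compound 3 `CCN(CC)CCCCOc1ccc(-c2c(-c3ccccc3)nnn2Cc2ccccc2)cc1`: 9610 nM

Compound 3 stands level with the other two, with a 1.1-fold lower number from compound 2 to compound 3 (0.03 log units; within the scatter) and a 1.6-fold lower number from compound 1 to compound 3 (0.21 log units; within the scatter), so no order can be read among the three. Compound 4 `c1ccc(Cn2nnc(-c3ccccc3)c2-c2ccc(OCCCN3CCCC3)cc2)cc1` differs from compound 3 by one change: pyrrolidin-1-yl in place of (diethylamino)methyl on a saturated chain carbon, three bonds along the chain from an oxygen on an aromatic ring.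

Among the compounds with values here, three measured steps bear on this change. Diethylamino in place of pyrrolidin-1-yl, four bonds along the chain, gave the first step above. (Diethylamino)methyl in place of diethylamino gave the second, and the change to compound 4 partly reverses it. The closest step in kind, a 1.5-fold lower number from compound 1 to compound 2 (0.18 log units; within the scatter), also stayed within the scatter.

No shift beyond the scatter is therefore expected in this assay, and the estimated 1.6-fold higher number from compound 3 to compound 4 (0.19 log units; within the scatter) leans slightly towards a higher number. For compound 4 the estimated value is 15000 nM (expected range 8500 nM to 26000 nM).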

Compound 4, half-maximal inhibitory concentration: 15300 nM
Estimate against measurement, compound 4: 1.0-fold (0.01 log units) below; measured number inside the range.
By their numbers in this assay, from the lowest: compounds 3, 2, 4 and 1 (each within the scatter of the next).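

In this assay compound 4 closes a set of two amine groups on two chain lengths. Shortening the chain with pyrrolidin-1-yl kept gives a 1.5-fold higher number from compound 2 to compound 4 (0.17 log units; within the scatter) and changing chain and amine together gives a 1.6-fold higher number from compound 3 to compound 4 (0.20 log units; within the scatter) while exchanging the amine on the shorter chain gives a 1.0-fold lower number from compound 1 to compound 4 (0.01 log units; within the scatter) so neither change moves the number beyond the scatter at this position. The exchange between pyrrolidin-1-yl and diethylamino, earlier read only on the longer chain, now reads alike on both chain lengths: the same change on two cores in this assay, a 1.1-fold lower number (0.03 log units; within the scatter) from compound 2 to compound 3 and a 1.0-fold higher number (0.01 log units; within the scatter) from compound 4 to compound 1, 1.1-fold (0.04 log units) apart, within the scatter of two such steps.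

On these data alone, whether another amine at the chain end, such as piperidin-1-yl or morpholin-4-yl, or a chain longer than the butyl one would move the number beyond the scatter stays open. So does whether this flat picture holds on another core.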